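Shifting a Hydroxyl on a Shared Core

The source may report more compounds than this note shows. Statements on the series, on what has been measured and on what is new or still open speak of the compounds shown alone.

Compound 1, `Oc1cccc(-c2cc(-c3ccccc3C(F)(F)F)cc(-c3ccccc3O)n2)c1`, in a functional assay on HCT-15 cells (Homo sapiens) for inhibition; on this read-out higher numbers stand for weaker inhibition and lower numbers for stronger inhibition: 9010 nM
Compound 2, `Oc1ccc(-c2cc(-c3ccccc3C(F)(F)F)cc(-c3ccccc3O)n2)cc1`, in this assay: 8990 nM

Compound 2 and compound 1 sit within the scatter of each other, so neither stands apart: the step of a 1.0-fold lower number from compound 1 to compound 2 (0.00 log units; within the scatter) is no real change. Compound 3, `Oc1ccc(-c2cc(-c3ccccc3C(F)(F)F)cc(-c3cccc(O)c3)n2)cc1`, differs from compound 2 by 3-hydroxyphenyl in place of 2-hydroxyphenyl on an aromatic carbon. Going by the values given here, the one measured step bearing on this, a 1.0-fold lower number from compound 1 to compound 2 (0.00 log units; within the scatter), also moved a hydroxyl around its ring and stayed within the scatter, so for compound 3 no step beyond the scatter is expected in this assay, namely a 1.0-fold higher number from compound 2 to compound 3 (0.00 log units; within the scatter). Compound 3 is therefore estimated at 9000 nM, between 4500 nM and 18000 nM.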

Compound 3, half-maximal inhibitory concentration: 5740 nM
Compound 3: middle estimate off by 1.6-fold (0.20 log units), on the high side; the range from low to high includes it.
By their numbers in this assay, from the lowest: compounds 3, 2 and 1 (each within the scatter of the next).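

Putting 3-hydroxyphenyl in place of 2-hydroxyphenyl on the aromatic carbon next to the ring nitrogen gives (a 1.6-fold lower number from compound 2 to compound 3 (0.19 log units; within the scatter)) in this assay. The swap of 2-hydroxyphenyl for 4-hydroxyphenyl gives (a 1.6-fold lower number from compound 1 to compound 3 (0.20 log units; within the scatter)), so all three hydroxyl arrangements shown read alike on the shared core. Nothing measured here explains this lack of separation.

Every compound shown still carries hydroxyl groups on these rings. From the compounds shown here alone, how a methoxy group, an amine or a carboxylic acid at this position would read remains open.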